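Thiophen-2-yl in place of 4-chlorophenyl: working notes

The source may report more compounds than this note shows. Statements on the series, on what has been measured and on what is new or still open speak of the compounds shown alone.

Values in a functional assay on SK-OV-3 cells (Homo sapiens) for antiproliferative activity, read by MTT assay, with a stated time of 24 h; a higher number here means a weaker inhibitor, a lower number a stronger inhibitor:
Compound 1 `COc1ccc(/C=C/C(=O)c2ccc(OC)c3c2OC(C)(C)C=C3)c(F)c1`: 4880 nM
Compound 2 `COc1ccc(C(=O)/C=C/c2ccc(N(C)C)cc2)c2c1C=CC(C)(C)O2`: 2750 nM
Compound 3 `COc1ccc(C(=O)/C=C/c2ccc(Cl)cc2)c2c1C=CC(C)(C)O2`: > 10000 nM

Compound 3 gives > 10000 nM, which is a limit of the assay and not a number. Two measured steps end at this limit: an at least 2.0-fold higher number from compound 1 to compound 3 (0.31 log units; beyond the scatter) and an at least 3.6-fold higher number from compound 2 to compound 3 (0.56 log units; beyond the scatter). The remaining step, a 1.8-fold lower number from compound 1 to compound 2 (0.25 log units; within the scatter), leaves no separation between those two compounds.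

Compound 4 `COc1ccc(C(=O)/C=C/c2cccs2)c2c1C=CC(C)(C)O2` has not yet been measured. It carries thiophen-2-yl in place of 4-chlorophenyl on a double-bonded chain carbon bound to a double-bonded chain carbon.

All three measured steps change the group at this same place, so all three bear on the new change, although none of them involves thiophen-2-yl. The largest, an at least 3.6-fold higher number from compound 2 to compound 3 (0.56 log units; beyond the scatter), shows that this place can move the number in this assay. Of the three groups, only the 4-chlorophenyl of compound 3 ends at a limit. Compound 1 at 4880 nM and compound 2 at 2750 nM give numbers. A partial return toward those numbers is expected, and another limit remains possible. The expected change in this assay is modest and is estimated as an at least 1.6-fold lower number from compound 3 to compound 4 (0.22 log units; that floor lies within the scatter). For compound 4 the estimated value is 6000 nM, with an expected range of 2500 nM to 14000 nM.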

Compound 4, half-maximal inhibitory concentration: > 10000 nM
Compound 4 ended at the assay's limit; the forecaster's own chance of this, stated with the estimate: 25%; middle value at least 1.6-fold (0.22 log units) from the limit.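

Thiophen-2-yl does not restore a readable number at this place on the double-bonded chain carbon: in this assay compound 4 gives > 10000 nM and this is a limit of the assay, not a number. Limits at this place are therefore not confined to 4-chlorophenyl, and among the four compounds numbers come only with 2-fluoro-4-methoxyphenyl and 4-(dimethylamino)phenyl, as the two readable steps show (an at least 3.6-fold higher number from compound 2 to compound 4 (0.56 log units; beyond the scatter) and an at least 2.0-fold higher number from compound 1 to compound 4 (0.31 log units; beyond the scatter)), both of them only lower bounds on the loss. The step between thiophen-2-yl and 4-chlorophenyl cannot be read, and no order can be given for these two groups, because both compounds sit at the same limit: the limit of > 10000 nM in this assay, at which 2 of the 4 values shown sit.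

On these data alone, how far compound 3 and compound 4 lie past that limit stays open, so a smaller five-membered ring cannot be ranked against the larger 4-chlorophenyl. Also open, as far as these compounds go, is whether the methoxy or dimethylamino group on the phenyl ring is what goes with a readable number, which a 4-hydroxyphenyl or a 4-aminophenyl at this place would test.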